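Swapping the Side Group on Compound 2

The source may report more compounds than this note shows. Statements on the series, on what has been measured and on what is new or still open speak of the compounds shown alone.

In a physicochemical assay for solubility (on this read-out higher numbers stand for higher solubility and lower numbers for lower solubility), compound 2 (`O=C(Cn1ccnc1)N1CCC(NS(=O)(=O)c2cc(S(=O)(=O)c3ccccc3)ccc2C(F)(F)F)CC1`) gives 100000 nM as its reading, level with compound 1 (`CN(C)CC(=O)N1CCC(NS(=O)(=O)c2cc(S(=O)(=O)c3ccccc3)ccc2C(F)(F)F)CC1`) at 100000 nM on the same scale. Compound 3 (`CC(C)(C)OC(=O)N1C(=O)CC[C@H]1C(=O)N1CCC(NS(=O)(=O)c2cc(S(=O)(=O)c3ccccc3)ccc2C(F)(F)F)CC1`) gives 50000 nM and stays within the scatter of both. Compound 4 (`CC(=O)N1CCC[C@H]1C(=O)N1CCC(NS(=O)(=O)c2cc(S(=O)(=O)c3ccccc3)ccc2C(F)(F)F)CC1`) differs from compound 2 in one place 1-acetylpyrrolidin-2-yl in place of (1H-imidazol-1-yl)methyl on a carbonyl carbon with 1-acetylpyrrolidin-2-yl in place of (1H-imidazol-1-yl)methyl on a carbonyl carbon. Among the measured compounds shown here, the only measured step of no change at the digits printed from compound 1 to compound 2 (within the scatter) changed a group in this same part of the molecule and is the main guide here. On that evidence, the expected step of a 1.4-fold lower number from compound 2 to compound 4 (0.15 log units; within the scatter) in this assay stays within the scatter. Compound 4 is estimated at 70000 nM with an expected range from 30000 nM to 110000 nM for its reading.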

Compound 4, solubility: 12500 nM
Beside the measured number, compound 4's estimate is 5.6-fold (0.75 log units) above it, and the stated range ends above it.
By their numbers in this assay, from the lowest: compound 4; then compounds 3, 1 and 2 (each within the scatter of the next).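

In this assay this carbonyl carbon does not accept every group alike: the swap of dimethylamino for 1H-imidazol-1-yl stayed within the scatter, whereas 1-acetylpyrrolidin-2-yl gives an 8.0-fold lower number from compound 2 to compound 4 (0.90 log units; beyond the scatter) and also an 8.0-fold lower number from compound 1 to compound 4 (0.90 log units; beyond the scatter). So the reading can move beyond the scatter through a change at this place alone. Nothing measured here explains the drop. Still open, from the compounds shown here alone, is which part of the entering group goes with the lower number: the acetyl group, the non-aromatic ring or the defined stereocentre. Also open, going by these compounds, is how a pyrrolidine without the acetyl group, or a carboxylic acid, would read here.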